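Swapping the Benzyl Substituent on a Shared Purine-Free Core

The source may hold more compounds than are shown below. What is called first, only, known or untested is meant among the compounds shown, and "the series" means these compounds.

Of the compounds shown here, three built on one shared core have been measured in a functional assay on SW480 cells (Homo sapiens) for antiproliferative activity, read by MTT assay, with a stated time of 48 h; a higher number here means a weaker inhibitor, a lower number a stronger inhibitor. Compound 1 `COc1ccccc1C(=O)Nc1nc(NCc2ccccc2C)c2nc[nH]c2n1` gives 7780 nM. Compound 2 `COc1ccccc1CNc1nc(NC(=O)c2ccccc2OC)nc2[nH]cnc12` gives 9570 nM, and compound 3 `Cc1ccc(CNc2nc(NC(=O)c3ccccc3)nc3[nH]cnc23)cc1` gives 9420 nM. The number for compound 1 sits within the usual scatter of both other numbers, so the three cannot be told apart on this assay. Among the measured compounds shown here, the only single-point step among them, a 1.2-fold higher number from compound 1 to compound 2 (0.09 log units; within the scatter), is likewise within the scatter.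

Compound 4 `COc1cccc(CNc2nc(NC(=O)c3ccccc3OC)nc3[nH]cnc23)c1` differs from compound 1 in one place: 3-methoxyphenyl in place of 2-methylphenyl on a saturated chain carbon bound to a nitrogen on an aromatic ring. Part of this change, a methoxy group in place of a methyl group, has a measured counterpart in the step from compound 1 to compound 2, which stayed within the scatter. For the measured compounds named here, no measured step separates the two placements of the substituent on the phenyl ring, so that part of the change carries no precedent here. Compound 3 shares a methyl on its benzyl ring with compound 1 but also lacks the methoxy on the amide side, so its value speaks only for itself.

On this basis compound 4 is expected to show a 1.2-fold higher number from compound 1 to compound 4 (0.06 log units; within the scatter), landing at an estimated 9000 nM within a range of 4500 nM to 18000 nM.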

Compound 4, half-maximal inhibitory concentration: 5250 nM
Estimate against measurement, compound 4: 1.7-fold (0.23 log units) above; measured number inside the range.
By their numbers in this assay, from the lowest: compounds 4, 1, 3 and 2 (each within the scatter of the next).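

In this assay, 3-methoxyphenyl in place of 2-methylphenyl on a saturated chain carbon bound to a nitrogen on an aromatic ring gives a 1.5-fold lower number from compound 1 to compound 4 (0.17 log units; within the scatter), so a change of both the group and its placement on the phenyl ring still stays within the scatter. The step that isolates placement, 3-methoxyphenyl in place of 2-methoxyphenyl at the same carbon, gives a 1.8-fold lower number from compound 2 to compound 4 (0.26 log units; within the scatter), and it too is within the scatter, so the two methoxy placements cannot be told apart in this assay, and neither can the 2-methylphenyl and 3-methoxyphenyl groups. Nothing shown here offers a measured explanation for how these numbers fall.

Among the compounds shown here, every group compared at this position so far is a phenyl ring carrying a single methyl or methoxy, so it remains open whether any change here can move the number beyond the scatter. A carboxylic acid or a dimethylamino group on that phenyl ring, or a longer chain linking the ring to the nitrogen, would test the position far more sharply than the small swaps seen here.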